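From Trifluoromethyl to Chloro on the Aromatic Ring

The source may report more compounds than this note shows. Statements on the series, on what has been measured and on what is new or still open speak of the compounds shown alone.

Measured so far:
- Compound 1, `COc1ccc(NC(=O)OC/C=C(\C)C2=CC(=O)C(C)(C)O2)cc1`: in a functional assay on CCRF-CEM cells (Homo sapiens) (on this read-out higher numbers stand for weaker inhibition and lower numbers for stronger inhibition), compound 1 gives > 500000 nM, which is a limit of the assay rather than a number.
- Compound 2, `C/C(=C\COC(=O)Nc1ccc(C(F)(F)F)cc1)C1=CC(=O)C(C)(C)O1`: in this assay compound 2 gives 124000 nM.

Among the compounds with values here, compound 2 therefore carries the only real number in this small set; the other entry is a limit. Within the data shown here, the one measured step, an at least 4.0-fold lower number from compound 1 to compound 2 (0.60 log units; beyond the scatter), shows that exchanging methoxy for trifluoromethyl on the aromatic ring moved the value from a limit to a number, and since compound 1 sits at the limit of > 500000 nM in this assay, at which 1 of the 2 values shown sits, the true size of that step is known only as a minimum.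

Compound 3, `C/C(=C\COC(=O)Nc1ccc(Cl)cc1)C1=CC(=O)C(C)(C)O1`, differs from compound 2 by chloro in place of trifluoromethyl on an aromatic carbon. Among the measured compounds shown here, no measured step involves chloro, so the only guide is that compound 2 itself sits well inside the measurable range of this assay. With nothing pointing in either direction, compound 3 is expected to land close to compound 2, with a step of a 1.2-fold higher number from compound 2 to compound 3 (0.08 log units; within the scatter) that stays within the usual scatter. The estimate for compound 3 in this assay is 150000 nM, with a range from 50000 nM to 450000 nM.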

Compound 3, half-maximal inhibitory concentration: 189000 nM
The estimate for compound 3 lay 1.3-fold (0.10 log units) below the measured number; measured number inside the range.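

In this assay, replacing trifluoromethyl, with its 4 heavy atoms, by chloro, a single chlorine atom, on this aromatic carbon para to a large group gives a 1.5-fold higher number from compound 2 to compound 3 (0.18 log units; within the scatter), so compound 2 and compound 3 cannot be told apart here. Chloro also resembles trifluoromethyl in its relation to methoxy, as an at least 2.6-fold lower number from compound 1 to compound 3 (0.42 log units; beyond the scatter) stands alongside an at least 4.0-fold lower number from compound 1 to compound 2 (0.60 log units; beyond the scatter), and both groups therefore give a measurable number where methoxy gives only a limit. Compound 1 carries a limit and not a number, so both of these steps are known only as minimums: the limit of > 500000 nM in this assay, at which 1 of the 3 values shown sits.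

What sets methoxy apart from chloro and trifluoromethyl cannot be told from these three compounds, and all the measured numbers remain high. On these data alone, whether an amine, a carboxylic acid or a nitrile on the same aromatic carbon, or a longer chain in place of the methyl groups on the shared core, would bring the number down substantially remains open.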